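This account rests on a few compounds, and the source may have more. Where it says the series, first, only, none or still open, it means among the compounds named here.

Working notes on the series.

Two compounds of the shared core carry a measurement. Compound 1 `CN(C)CCCOc1c(OCc2ccccc2)cc(O)c2c(=O)cc(-c3ccccc3)oc12` gives, in a functional assay on MCF7 cells (Homo sapiens) for cytotoxicity, read by MTT assay, with a stated time of 72 h (on this read-out lower numbers stand for stronger inhibition and higher numbers for weaker inhibition), a value of 3210 nM. Compound 2 `Cc1ccc(COc2cc(O)c3c(=O)cc(-c4ccccc4)oc3c2OCCCCN2CCN(C)CC2)cc1` gives in this assay a value of 2220 nM, the lowest of the two numbers; the gap to compound 1 is within the scatter of repeated measurements, so no order between them can be read from these data.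

Compound 3 `CN1CCN(CCCCOc2c(OCc3nc4ccccc4s3)cc(O)c3c(=O)cc(-c4ccccc4)oc23)CC1` is not yet measured in this assay. Its difference from compound 2 is 1,3-benzothiazol-2-yl in place of 4-methylphenyl on a saturated chain carbon bound to an oxygen on an aromatic ring. For the measured compounds named here, no measured pair shows this change, so nothing in the data anchors its size or direction. The step from compound 2 to compound 3 is therefore expected to be a 1.1-fold lower number from compound 2 to compound 3 (0.05 log units; within the scatter), not clearly beyond the scatter. On that basis compound 3 is estimated to give 2000 nM in this assay, with a range from 700 nM to 6000 nM.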

Compound 3, half-maximal inhibitory concentration: 4850 nM
Compound 3: middle estimate off by 2.4-fold (0.38 log units), on the low side; the measured number falls inside the stated range.
By their numbers in this assay, from the lowest: compounds 2, 1 and 3 (each within the scatter of the next, the first and the last beyond it).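

In this assay, for the compounds shown here, 1,3-benzothiazol-2-yl in place of 4-methylphenyl on a saturated chain carbon bound to an oxygen on an aromatic ring gives a 2.2-fold higher number from compound 2 to compound 3 (0.34 log units; beyond the scatter) and is the first step beyond the scatter, though a modest one. The number at this position therefore responds to the group it carries, and here the entering group, with its nitrogen and sulfur and its five-membered aromatic ring, goes with the higher number. No measurement in hand accounts for this step.

The compounds shown leave open whether the step follows the hetero atoms or the second ring, which a pyridin-2-yl or a naphthyl group at this position would help to separate. As far as these compounds go, it also remains open whether the step would hold with a morpholine in place of the methylpiperazine at the end of the chain.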